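Lengthening the Benzyl Arm of a Calpain Inhibitor

The source may report more compounds than this note shows. Statements on the series, on what has been measured and on what is new or still open speak of the compounds shown alone.

Compound 2 `CCC(NC(=O)C(CC(C)C)NC(=O)OCc1ccccc1)C(=O)C(=O)NCc1ccccc1` holds the lower of the two numbers measured in an assay on isolated protein (Oryctolagus cuniculus) for inhibition of Calpain-2 catalytic subunit (Homo sapiens), at pH 8.0; on this read-out lower numbers stand for stronger inhibition and higher numbers for weaker inhibition: compound 2 gives 22 nM, while compound 1 `CCOC(=O)C(=O)C(CC)NC(=O)C(CC(C)C)NC(=O)OCc1ccccc1` gives 400 nM. For the measured compounds named here, the single measured step, an 18-fold lower number from compound 1 to compound 2 (1.26 log units; beyond the scatter), came with benzylamino in place of ethoxy on a carbonyl carbon. Compound 3 `CCC(NC(=O)C(CC(C)C)NC(=O)OCc1ccccc1)C(=O)C(=O)NCCCc1ccccc1` has not yet been measured in this assay. It differs from compound 2 by phenethyl in place of phenyl on a saturated chain carbon bound to an amide-type nitrogen, so the aromatic ring is moved further out along a longer chain while everything else stays the same. Going by the values given here, no measured step bears on a change of this kind: the only step, from compound 1 to compound 2, exchanged the group on the carbonyl carbon and did not lengthen a chain, so it offers no direct guide. The expectation is therefore a step of a 1.1-fold higher number from compound 2 to compound 3 (0.06 log units; within the scatter), nothing beyond the scatter. Compound 3 is estimated at 25 nM in this assay, with a range from 8 nM to 80 nM.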

Compound 3, inhibition constant: 43 nM
Compound 3: middle estimate off by 1.7-fold (0.24 log units), on the low side, and the stated range covers the measured number.
By their numbers in this assay, from the lowest: compounds 2 and 3 (each within the scatter of the next); then compound 1.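

In this assay, swapping benzyl for 3-phenylpropyl on the amide-type nitrogen gave a 2.0-fold higher number from compound 2 to compound 3 (0.29 log units; within the scatter) and so left the reading within the usual scatter, which shows that this position accepts the aromatic ring further out along a longer chain. The advantage over the ethoxy group also survives this lengthening, with a 9.3-fold lower number from compound 1 to compound 3 (0.97 log units; beyond the scatter) and so remains beyond the scatter, showing that it is not confined to benzylamino. No measurement here accounts for either result.

A still longer chain between the nitrogen and the phenyl ring remains an open question, as does a plain propyl group with no ring at its end. From the compounds shown here alone, how a carboxylic acid or an amine on the phenyl ring would read in this assay is also open.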